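The source may report more compounds than this note shows. Statements on the series, on what has been measured and on what is new or still open speak of the compounds shown alone.

In an ADME assay on HEK-293T cells (Homo sapiens) for cytotoxicity, read by MTT assay, with a stated time of 72 h (on this read-out higher numbers stand for weaker inhibition and lower numbers for stronger inhibition), compound 1 (`O=C(Nc1nc2ccccc2s1)c1cn(-c2ccccc2)nc1-c1ccccc1`) gives > 50000 nM, a limit of the assay and not a number. Within the data shown here, compound 2 (`Cc1ccc2nc(NC(=O)c3cn(-c4ccccc4)nc3-c3ccccc3)sc2c1`) gives > 50000 nM, also a limit, so the series so far stands at the limit of > 50000 nM in this assay, at which 2 of the 2 values shown sit.

Compound 3 (`COc1ccc(-c2nn(-c3ccccc3)cc2C(=O)Nc2nc3ccccc3s2)cc1`) has methoxy in place of hydrogen on an aromatic carbon of compound 1, para to a large group, which reads as phenyl to 4-methoxyphenyl: methoxy in place of hydrogen on an aromatic carbon.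

Among the measured compounds shown here, the only measured step that bears on this is a step that the two limits leave unreadable from compound 1 to compound 2, with methyl in place of hydrogen on an aromatic carbon. It gives no size to carry over, and no direction. No shift beyond the scatter is therefore expected in this assay, and the estimated step is a number no higher from compound 1 to compound 3 (the limit leaves the size open). For compound 3 the expected value is 50000 nM, with an estimated range of 20000 nM to 100000 nM, and a report as a limit is the likeliest outcome.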

Compound 3, half-maximal inhibitory concentration: 18900 nM
The estimate for compound 3 lay 2.6-fold (0.42 log units) above the measured number; measured number outside the range, below it.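

In this assay, among these compounds, methoxy para to a large group, the change from phenyl to 4-methoxyphenyl, gives an at least 2.6-fold lower number from compound 1 to compound 3 (0.42 log units; beyond the scatter), the first step that can be read. Going by these compounds, compound 1 gives > 50000 nM, a limit and not a number, so the step has a direction but its full size stays open. Compound 3 is the only compound shown with a measured number, and the rest of the series stays at the limit: the limit of > 50000 nM in this assay, at which 2 of the 3 values shown sit.

The step from compound 1 to compound 2 cannot be read, so the methoxy change cannot be set against the methyl change. On these data alone, whether an amine, a hydroxy or a longer alkoxy chain in the same place would shift the number further remains open.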